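A few compounds are considered here, and "the series" means these few. Any claim that something is new, unique, unknown or untested is made for them only; others in the source may bear on it.

Compound 3 `N#CCCc1cc(=O)oc2cc(OCc3cccc(Cl)c3)ccc12` is one of three measured compounds that share a core and differ only at one chain. In an assay on brain (strain Sprague-Dawley) for inhibition of Amine oxidase [flavin-containing] B (Rattus norvegicus), read by spectrophotometry (a lower number here means a stronger inhibitor, a higher number a weaker inhibitor), compound 3 gives 28.8 nM. Compound 1 `O=c1cc(CCBr)c2ccc(OCc3cccc(Cl)c3)cc2o1` gives 32.4 nM, and compound 2 `NC(=O)CCc1cc(=O)oc2cc(OCc3cccc(Cl)c3)ccc12` gives 15.1 nM, so compound 3 sits with each of them inside the scatter. Compound 4 `O=C(CCl)Nc1cc(=O)oc2cc(OCc3cccc(Cl)c3)ccc12` differs from compound 3 on the same aromatic carbon: ((chloromethyl)carbonyl)amino in place of 2-cyanoethyl on an aromatic carbon. The measured steps changed only the chain end: a 2.1-fold lower number from compound 1 to compound 2 (0.33 log units; beyond the scatter), a 1.1-fold lower number from compound 1 to compound 3 (0.05 log units; within the scatter) and a 1.9-fold higher number from compound 2 to compound 3 (0.28 log units; within the scatter), all small. The new group is counted as carrying one hydrogen-bond donor, yet those earlier swaps point to little movement, so the step of a 1.2-fold lower number from compound 3 to compound 4 (0.06 log units; within the scatter) is expected to stay close to the scatter. Compound 4 is therefore estimated at 25 nM, within 8 nM to 80 nM.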

Compound 4, half-maximal inhibitory concentration: 398 nM
Estimate against measurement, compound 4: 16-fold (1.20 log units) below; measured number outside the range, above it.
By their numbers in this assay, from the lowest: compounds 2, 3 and 1 (each within the scatter of the next, the first and the last beyond it); then compound 4.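

In this assay, this aromatic carbon proves far less forgiving than the chain-end swaps suggested: putting ((chloromethyl)carbonyl)amino on it gives a 14-fold higher number from compound 3 to compound 4 (1.14 log units; beyond the scatter), a 26-fold higher number from compound 2 to compound 4 (1.42 log units; beyond the scatter) and a 12-fold higher number from compound 1 to compound 4 (1.09 log units; beyond the scatter). All three steps are large, so replacing the whole group counts for far more here than changing only the chain end did. Nothing measured here gives a reason for this jump. Compound 4 changes both the atom attached to the aromatic carbon and the chain end, and the compounds shown cannot separate these two changes. An acetylamino group or a simple amine on this carbon could help tell them apart.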